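Working notes: ring swap on the amide nitrogen

The source may hold more compounds than are shown below. What is called first, only, known or untested is meant among the compounds shown, and "the series" means these compounds.

Compound 1 `N#C[C@H](COCc1ccccc1)NC(=O)[C@@H](CC(=O)N1CCOCC1)CC1CCCCC1` gives 4.39 nM in an assay on isolated protein for inhibition of cathepsin S (Homo sapiens); on this read-out higher numbers stand for weaker binding and lower numbers for tighter binding. Compound 2 `CN1CCC(C#N)(NC(=O)[C@@H](CC(=O)N2CCOCC2)CC2CCCCC2)CC1` gives 177 nM in this assay, the highest number of the two measured, standing beyond the scatter above compound 1. Compound 3 `CC(C)N1CC[C@@](C#N)(NC(=O)[C@@H](CC(=O)N2CCOCC2)CC2CCCCC2)C1` differs from compound 2 by 3-cyano-1-isopropylpyrrolidin-3-yl in place of 4-cyano-1-methylpiperidin-4-yl on an amide-type nitrogen. Going by the values given here, no measured pair shows this change, so its direction cannot be read from the data; a step of moderate size in either direction, or none beyond the scatter, is expected, and the estimate is the step of a 1.2-fold lower number from compound 2 to compound 3 (0.07 log units; within the scatter). Compound 3 is therefore expected to give 150 nM in this assay, with a range from 30 nM to 800 nM.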

Compound 3, dissociation constant: 60.6 nM
Compound 3: middle estimate off by 2.5-fold (0.39 log units), on the high side; low and high end bracket the measured number.
By their numbers in this assay, from the lowest: compound 1; then compound 3; then compound 2.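

On the amide-type nitrogen, 3-cyano-1-isopropylpyrrolidin-3-yl in place of 4-cyano-1-methylpiperidin-4-yl gives, in this assay, a 2.9-fold lower number from compound 2 to compound 3 (0.47 log units; beyond the scatter). This position therefore responds to a change of the nitrile-bearing ring and its nitrogen substituent, although ring size, substituent and the defined stereocentre all change in this single step. Nothing available bears on the cause of the step.

How the step divides among these changes stays open; 3-cyano-1-methylpyrrolidin-3-yl would separate ring size from the isopropyl group. Going by these compounds, the effect of the opposite configuration at the stereocentre also stays open.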